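The source may report more compounds than this note shows. Statements on the series, on what has been measured and on what is new or still open speak of the compounds shown alone.

Working notes on the series. In an ADME assay (liver) for metabolic stability, with Liver microsome (Homo sapiens) as the target, read by LC-MS, using microsomes, with a stated time of 30 min, tested at 4 uM (on this read-out higher numbers stand for a more stable compound and lower numbers for a less stable compound), compound 3 (`Cc1nc(N2CCN(C)CC2)c2nc(-c3ccccc3F)n(C3CCOCC3)c2n1`) gives 10%, the lowest of the three numbers, while compound 1 (`Cc1nc(N2CCN(C)CC2)c2nc(-c3cccc(Cl)c3)n(C3CCOCC3)c2n1`) gives 25% and compound 2 (`COc1cccc(-c2nc3c(N4CCN(C)CC4)nc(C)nc3n2C2CCOCC2)c1`) gives 40%.

Compound 4 (`Cc1nc(N2CCN(C)CC2)c2nc(-c3ccccc3C3CC3)n(C3CCOCC3)c2n1`) differs from compound 3 as follows: cyclopropyl in place of fluoro on an aromatic carbon. This is cyclopropyl in place of fluoro on an aromatic carbon, ortho to a large group.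

Three measured steps change the same aromatic substituent: a number 15 percentage points higher from compound 1 to compound 2 (beyond the scatter), a number 15 percentage points lower from compound 1 to compound 3 (beyond the scatter) and a number 30 percentage points lower from compound 2 to compound 3 (beyond the scatter). All are modest and beyond the scatter, so this position can move the read-out by that much. None of the measured compounds carries cyclopropyl, so the direction of the new step is not shown directly. The value of 10% for compound 3 leaves little room for a fall, so the expected change is small and slightly upward, within the scatter.

The expected step is a number 4 percentage points higher from compound 3 to compound 4 (within the scatter). For compound 4 the estimated value is 14%, with an expected range of 4% to 32%.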

Compound 4, percent of the compound remaining: 33%
Estimate against measurement, compound 4: 19 percentage points below; measured number above the stated range.
By their numbers in this assay, from the lowest: compound 3; then compounds 1, 4 and 2 (each within the scatter of the next, the first and the last beyond it).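

In this assay, a number 23 percentage points higher from compound 3 to compound 4 (beyond the scatter), so with cyclopropyl in place of fluoro, this place, ortho to a large group, shows a modest step upward from the lowest number of the series. Compound 4 cannot be ordered against the other two, with a number 7 percentage points lower from compound 2 to compound 4 (within the scatter) and a number 8 percentage points higher from compound 1 to compound 4 (within the scatter), although a number 15 percentage points higher from compound 1 to compound 2 (beyond the scatter). Nothing at hand bears on why the number moves.

Going by these compounds, whether methyl, a longer chain or an amine in the same place would give a similar step remains open. The step also rests on a single pair, so it is unclear whether it would hold with other changes to the shared core.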